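Adding an Amino Group to Two Chloromethylbenzyl Purines

The compounds below may be only part of what the source reports. "The series", "measured", "known", "first", "only" and "open" are said of these compounds alone.

Compound 1 `ClCc1ccc(Cn2cnc3c(Cl)ncnc32)cc1` and compound 3 `ClCc1ccccc1Cn1cnc2c(Cl)ncnc21` contain the same atoms joined differently; the difference between the two cores is not broken down here. In a functional assay on HOP-62 cells (Homo sapiens) for cytotoxicity, read by sulforhodamine B assay, with a stated time of 48 h (on this read-out lower numbers stand for stronger inhibition of growth and higher numbers for weaker inhibition of growth), compound 1 gives 6760 nM, and compound 3 gives 6020 nM; these two numbers lie within the usual scatter of each other, so no order can be read between them.

Compound 2 `Nc1nc(Cl)c2ncn(Cc3ccc(CCl)cc3)c2n1` is compound 1 with a single change: amino in place of hydrogen on an aromatic carbon. In this assay compound 2 gives 27500 nM, and the step is a 4.1-fold higher number from compound 1 to compound 2 (0.61 log units; beyond the scatter). In a read-out where a larger number means weaker growth inhibition, this amounts to a loss of potency.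

Compound 4 `Nc1nc(Cl)c2ncn(Cc3ccccc3CCl)c2n1` has not yet been measured. It relates to compound 3 exactly as compound 2 relates to compound 1, and the change is the same: amino in place of hydrogen on an aromatic carbon. The change appears twice among these four compounds and has been measured once. That one measured step is the only basis for an expectation, since nothing else here bears on the amino group.

Compound 4 is therefore expected to give about 24500 nM in this assay. The expected step is a 4.1-fold higher number from compound 3 to compound 4 (0.61 log units; beyond the scatter), matching the earlier step in size. The likely range for compound 4 is expected to run from 10000 nM to 60000 nM.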

Compound 4, concentration for total growth inhibition: 61700 nM
Compound 4: middle estimate off by 2.5-fold (0.40 log units), on the low side; the whole stated range lies below it.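

Setting an amino group between two ring nitrogen atoms gives a 10-fold higher number from compound 3 to compound 4 (1.01 log units; beyond the scatter) in this assay, so on the core of compound 3, as on the core of compound 1, the amino compound inhibits growth more weakly. Set side by side, the two steps point the same way, and the gap between their sizes is no larger than ordinary scatter: the same change on two cores in this assay, a 4.1-fold higher number (0.61 log units; beyond the scatter) from compound 1 to compound 2 and a 10-fold higher number (1.01 log units; beyond the scatter) from compound 3 to compound 4, 2.5-fold (0.40 log units) apart, within the scatter of two such steps. The direction of the change therefore carried over from one core to the other, and there is no ground for saying that it costs more on one core than on the other, but two pairs of compounds show neither that it would hold on a further core nor why the amino group has this effect.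

All the changes shown here involve the same amino group at the same place, so it remains open how a methylamino group, a dimethylamino group or a methoxy group would behave there. The chloro group and the chloromethyl group are present in all four compounds, which leaves open whether the same step would appear if the chloromethyl group gave way to a hydroxymethyl group or a plain methyl group.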